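From compound 3 to compound 4: an estimate

The compounds below may be only part of what the source reports. "The series", "measured", "known", "first", "only" and "open" are said of these compounds alone.

Compound 1 `Cc1ccccc1Nc1nc(Nc2ccc(N3CCN(C)CC3)cc2)ncc1Cl` gives 6510 nM
Compound 2 `CN1CCN(c2ccc(Nc3ncc(Cl)c(NCc4ccccc4)n3)nc2)CC1` gives 20300 nM
Compound 3 `COc1cccc(CNc2nc(Nc3ccc(N4CCN(C)CC4)cn3)ncc2Cl)c1` gives 16200 nM

These values come from an ADME assay on L02 cells (Homo sapiens) for inhibition, read by CCK-8 assay, with a stated time of 48 h (on this read-out higher numbers stand for weaker inhibition of growth and lower numbers for stronger inhibition of growth), where compound 3 stands within the scatter of compound 2 and, beyond the scatter, above compound 1. Compound 4 `CCc1ccc(Nc2nc(Nc3ccc(N4CCN(C)CC4)cn3)ncc2Cl)cc1` remains unmeasured. It differs from compound 3 as follows: 4-ethylphenyl in place of 3-methoxybenzyl on a nitrogen on an aromatic ring. Going by the values given here, the one measured step, a 1.3-fold lower number from compound 2 to compound 3 (0.10 log units; within the scatter), concerns only a methoxy group and gives no size for this exchange. Among the compounds with values here, compound 1, the only measured compound without a benzyl group, gives 6510 nM but also differs elsewhere. A modest move to a lower number is therefore expected, on thin evidence. For compound 4 the estimate is 9500 nM, with an expected range from 3500 nM to 22000 nM. The estimated change is a 1.7-fold lower number from compound 3 to compound 4 (0.23 log units; within the scatter).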

Compound 4, concentration for 50% growth inhibition: 12100 nM
Estimate against measurement, compound 4: 1.3-fold (0.11 log units) below; low and high end bracket the measured number.
By their numbers in this assay, from the lowest: compounds 1, 4, 3 and 2 (each within the scatter of the next, the first and the last beyond it).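

In this assay the exchange of the whole group on this nitrogen gives a 1.3-fold lower number from compound 3 to compound 4 (0.13 log units; within the scatter) and, starting from plain benzyl, a 1.7-fold lower number from compound 2 to compound 4 (0.22 log units; within the scatter) as its result. The earlier compounds had shown only a methoxy step on the benzyl group, whereas these steps show that replacing that group with 4-ethylphenyl also stays within the scatter. No measurement at hand accounts for this result.

As far as these compounds go, whether an amine or a carboxylic acid on the phenyl ring, or a chain longer than ethyl, would carry the number beyond the scatter remains open.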